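From propanoyl to acetyl on the shared core

The source may hold more compounds than are shown below. What is called first, only, known or untested is meant among the compounds shown, and "the series" means these compounds.

Measured in an ADME assay on L929 cells (Mus musculus) for cytotoxicity, with a stated time of 72 h; a higher number here means a weaker inhibitor, a lower number a stronger inhibitor:
- compound 1 `CCOC(=O)C(C)Oc1ccc2c(c1)B(O)OC2`: > 10 ug/mL
- compound 2 `CCC(=O)C(C)Oc1ccc2c(c1)B(O)OC2`: > 10 ug/mL

Compound 2 has no number in this assay: compound 2 gives > 10 ug/mL, which is a limit of the assay. Compound 1 gives > 10 ug/mL, which is also a limit. All that is known so far is the limit of > 10 ug/mL in this assay, at which 2 of the 2 values shown sit.

Compound 3 `CC(=O)C(C)Oc1ccc2c(c1)B(O)OC2` has yet to be measured. It differs from compound 2 by hydrogen in place of methyl on a saturated chain carbon bound to a carbonyl carbon. The same difference can be read as propanoyl to acetyl.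

Among the compounds with values here, only one measured step bears on this change, a step that the two limits leave unreadable from compound 1 to compound 2. It offers no size to carry over, so no step beyond the scatter is expected in this assay, and no direction can be favoured. The estimated step is a step that the limit leaves unreadable from compound 2 to compound 3. Compound 3 is expected to remain at the same limit as compound 2, which gives > 10 ug/mL. For compound 3 the estimated value is 20 ug/mL, with an expected range of 10 ug/mL to 60 ug/mL.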

Compound 3, half-maximal inhibitory concentration: > 10 ug/mL
Compound 3: only a limit was reported; the forecaster's own chance of this, stated with the estimate: 85%; the middle value is on the limit's open side.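

In this assay compound 3 gives > 10 ug/mL, which is a limit and not a number. No step among compound 1, compound 2 and compound 3 can be read, and all three stand at the same point: the limit of > 10 ug/mL in this assay, at which 3 of the 3 values shown sit.

The compounds shown leave open how far their cytotoxicity lies beyond that limit and whether the changes on the carbonyl carbon alter it at all.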